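This account rests on a few compounds, and the source may have more. Where it says the series, first, only, none or still open, it means among the compounds named here.

Compound 1 `CCOC(=O)C1=C(C)N(c2ccccc2)C=CC1c1ccccc1` in a functional assay, tested at 100 ug/mL (a lower number here means a stronger effect, a higher number a weaker effect of the compound at the concentration tested), gives -21.5%
Compound 2 `COC(=O)C1=C(C)N(c2ccccc2)C=CC1c1ccccc1` in this assay gives -25.9%
Compound 3 `COC(=O)C1=C(C)N(c2ccccc2)C=CC1c1ccc(OC)cc1` in this assay gives -29.8%

Among these three numbers compound 2 stands second highest; its nearest neighbour is compound 3 and its furthest is compound 1, and both of those distances fall within the scatter. The step from compound 2 to compound 4 `CC1=C(C(=O)OC(C)(C)C)C(c2ccccc2)C=CN1c1ccccc1` is tert-butyl in place of methyl on an oxygen next to a carbonyl group. Going by the values given here, the one measured step that bears on it directly is the earlier change at the same place, hydrogen in place of methyl on a saturated chain carbon bound to an oxygen next to a carbonyl group, which gave a number 4.4 percentage points lower from compound 1 to compound 2 (within the scatter). The change on the aromatic carbon, a number 3.9 percentage points lower from compound 2 to compound 3 (within the scatter), sits elsewhere and says little about compound 4. Among the compounds with values here, since the one relevant step stayed within the scatter, compound 4 is expected to show no step beyond the scatter in this assay, with the estimated step of a number 2.9 percentage points higher from compound 2 to compound 4 (within the scatter). Compound 4 is therefore estimated at -23%, within a range from -36% to -10%.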

Compound 4, a percentage reported as activity, at one concentration (the size of the read-out at that concentration, not a potency): -30.7%
For compound 4 the middle estimate is 7.7 percentage points above the measured one; low and high end bracket the measured number.
By their numbers in this assay, from the lowest: compounds 4, 3, 2 and 1 (each within the scatter of the next).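

In this assay tert-butyl in place of methyl on the oxygen next to a carbonyl group gives a number 4.8 percentage points lower from compound 2 to compound 4 (within the scatter) and tert-butyl in place of ethyl gives a number 9.2 percentage points lower from compound 1 to compound 4 (within the scatter) at the same place. The earlier compounds shown here had covered only methyl and ethyl here, whereas compound 4 shows that tert-butyl, with its four carbons, also leaves the read-out within the scatter of both. Nothing in the data shown gives a reason for these steps.

On these data alone, it stays open whether a carboxylic acid, an amide or a longer chain such as n-butyl in this place would also stay within the scatter, and whether tert-butyl would do so alongside the methoxy group of compound 3. As far as these compounds go, each number comes from a single concentration, so whether the effect would be stronger or weaker at other concentrations also remains open.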